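Solubility notes: saturated to aromatic ring on the amide carbonyl

This account rests on a few compounds, and the source may have more. Where it says the series, first, only, none or still open, it means among the compounds named here.

Measured so far:
compound 1, `O=C(Nc1ccc(C(F)(F)F)cc1)NC1CCN(C(=O)C2CCCOC2)CC1`: 25 ug/mL
compound 2, `O=C(Nc1ccc(OC(F)(F)F)cc1)NC1CCN(C(=O)C2CCOC2)CC1`: 91 ug/mL

Two compounds of the shared core have been run in a physicochemical assay for solubility, read by mass spectrometry, in phosphate buffer, with a stated time of 24 h, at pH 3; on this read-out lower numbers stand for lower solubility and higher numbers for higher solubility. Compound 1 stands lowest of the two numbers; its nearest neighbour is compound 2, whose value lies higher by a margin beyond the scatter. Among the compounds with values here, no pair of measured compounds differs in a single place, so no measured step is available.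

Compound 3, `O=C(Nc1ccc(C(F)(F)F)cc1)NC1CCN(C(=O)c2ccoc2)CC1`, is not yet measured. It differs from compound 1 in one place: furan-3-yl in place of oxan-3-yl on a carbonyl carbon. Within the data shown here, with no measured step of this kind to lean on, the expectation rests on the value of compound 1 alone. A moderate downward step a 2.1-fold lower number from compound 1 to compound 3 (0.32 log units; beyond the scatter) is expected, somewhat beyond the scatter but not large. Compound 3 is accordingly estimated at 12 ug/mL, with a range from 4 ug/mL to 40 ug/mL.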

Compound 3, solubility: 6 ug/mL
Compound 3: the middle estimate sits 2.0-fold (0.30 log units) above what was measured; the range from low to high includes it.
By their numbers in this assay, from the lowest: compound 3; then compound 1; then compound 2.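

In this assay, within the data shown here, the group on the carbonyl carbon is the first place with a readable single change: furan-3-yl in place of oxan-3-yl gives a 4.2-fold lower number from compound 1 to compound 3 (0.62 log units; beyond the scatter). The read-out therefore responds to this position, even though the count of hydrogen-bond donors and acceptors and the absence of net charge stay the same across the change. Nothing on hand bears on why the number moves.

Ring size and aromatic character change together in this single step, so the step cannot assign the change to either one, and a pyridin-3-yl group on the same carbonyl carbon would keep the six-membered ring while making it aromatic. On these data alone, how an amine or a carboxylic acid on this ring would read in this assay also remains open.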